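A few compounds are considered here, and "the series" means these few. Any claim that something is new, unique, unknown or untested is made for them only; others in the source may bear on it.

In a functional assay on T47D cells (Homo sapiens) for inhibition, read by sulforhodamine B assay, with a stated time of 48 h (a higher number here means a weaker inhibitor of growth, a lower number a stronger inhibitor of growth), compound 2 `COC(=O)[C@@]1(C)CCC=C2[C@@H]1CC[C@@H](C)[C@]2(C)Cc1c[nH]c2ccc(F)cc12` gives 3900 nM, the lowest of the three numbers. Compound 1 `COC(=O)[C@@]1(C)CCC=C2[C@@H]1CC[C@@H](C)[C@]2(C)Cc1c[nH]c2ccc(Cl)cc12` gives 17000 nM and compound 3 `COC(=O)[C@@]1(C)CCC=C2[C@@H]1CC[C@@H](C)[C@]2(C)Cc1c[nH]c2ccc(C(F)(F)F)cc12` gives 15000 nM. The steps of a 4.4-fold lower number from compound 1 to compound 2 (0.64 log units; beyond the scatter) and a 3.8-fold higher number from compound 2 to compound 3 (0.59 log units; beyond the scatter) set compound 2 apart from both others, while the step of a 1.1-fold lower number from compound 1 to compound 3 (0.05 log units; within the scatter) is flat. Compound 4 `COC(=O)[C@@]1(C)CCC=C2[C@@H]1CC[C@@H](C)[C@]2(C)Cc1c(C)[nH]c2ccc(F)cc12` differs from compound 2 by methyl in place of hydrogen on an aromatic carbon. Within the data shown here, no measured step bears on this change: all three swaps above are exchanges of one aromatic substituent for another elsewhere on the fused system, so nothing here tells what a methyl at this place does. The expectation is therefore a step no larger than the scatter in this assay, in no set direction, no change at the digits printed from compound 2 to compound 4 (within the scatter). The estimate for compound 4 is 3900 nM, with a range of 1300 nM to 12000 nM.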

Compound 4, concentration for 50% growth inhibition: 15000 nM
Compound 4: middle estimate off by 3.8-fold (0.59 log units), on the low side, outside the stated range (above it).
By their numbers in this assay, from the lowest: compound 2; then compounds 3, 4 and 1 (each within the scatter of the next).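

The step of a 3.8-fold higher number from compound 2 to compound 4 (0.59 log units; beyond the scatter) in this assay shows that this position, on an aromatic carbon of the five-membered aromatic ring and next to the ring nitrogen, is sensitive to a single methyl in place of hydrogen. Among these compounds, the earlier compounds varied only the other aromatic substituent, so this is the first reading at this place, and here the added methyl weakens growth inhibition with fluoro held fixed. Nothing available accounts for the step.

Still open, on these data alone, is whether methyl here has the same effect alongside chloro or trifluoromethyl. Also open, as far as these compounds go, is how ethyl, a longer chain or a carboxylic acid at this place would read.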